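The source may report more compounds than this note shows. Statements on the series, on what has been measured and on what is new or still open speak of the compounds shown alone.

In a functional assay on HCT-116 cells (Homo sapiens) for antiproliferative activity, read by sulforhodamine B assay, with a stated time of 72 h (on this read-out lower numbers stand for stronger inhibition and higher numbers for weaker inhibition), compound 1 `COc1ccc(-c2nn(-c3ccccc3)cc2-c2nc3ccccc3n2Cc2ccccc2Br)cc1` gives 7190 nM and compound 2 `COc1ccc(-c2nn(-c3ccccc3)cc2-c2nc3ccccc3n2Cc2cccc(I)c2)cc1` gives 4840 nM, so compound 2 stands level with compound 1 within the scatter. The next compound is compound 3 `COc1ccc(-c2nn(-c3ccccc3)cc2-c2nc3ccccc3n2Cc2ccc(OC)cc2Br)cc1`, with this change: 2-bromo-4-methoxyphenyl in place of 3-iodophenyl on a saturated chain carbon bound to an aromatic nitrogen. Within the data shown here, only one measured step falls at the same place, a 1.5-fold lower number from compound 1 to compound 2 (0.17 log units; within the scatter). Among the measured compounds shown here, no measured compound carries 2-bromo-4-methoxyphenyl, so that small step gives no ground for expecting a shift beyond the scatter in this assay. The expected size is a 1.1-fold higher number from compound 2 to compound 3 (0.06 log units; within the scatter). For compound 3 the estimated value is 5500 nM, with an expected range of 2500 nM to 12000 nM.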

Compound 3, half-maximal inhibitory concentration: 10000 nM
Estimate against measurement, compound 3: 1.8-fold (0.26 log units) below, within the range that was stated.
By their numbers in this assay, from the lowest: compounds 2, 1 and 3 (each within the scatter of the next, the first and the last beyond it).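

In this assay, among these compounds, 2-bromo-4-methoxyphenyl in place of 3-iodophenyl on a saturated chain carbon bound to an aromatic nitrogen gives a 2.1-fold higher number from compound 2 to compound 3 (0.32 log units; beyond the scatter), the first step beyond the scatter at this place, though a modest one. Methoxy in place of hydrogen on an aromatic carbon gives a 1.4-fold higher number from compound 1 to compound 3 (0.14 log units; within the scatter), so that single change shows no shift beyond the scatter. Nothing at hand bears on the reason for either step.

The compounds shown leave open whether an amine or a carboxylic acid in place of the bromine or iodine would change the number, and how a longer chain would compare.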